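Ethoxycarbonyl to isopropoxycarbonyl: working notes on the series

A few compounds are considered here, and "the series" means these few. Any claim that something is new, unique, unknown or untested is made for them only; others in the source may bear on it.

- compound 1 `CCCCC(=O)N1CCC(N2CCN(C(=O)c3c(NC(=O)NCC)sc4ccccc34)CC2)CC1`: "not determined" (no result reported)
- compound 2 `CCNC(=O)Nc1sc2ccccc2c1C(=O)N1CCN(C2CCN(C(=O)OCC)CC2)CC1`: 228 nM

For the measured compounds named here, in a functional assay on HepG2 cells (Homo sapiens) for inhibition, read by scintillation counting, with a stated time of 2 h (on this read-out higher numbers stand for weaker inhibition and lower numbers for stronger inhibition), compound 2 holds the only number so far (228 nM), so it can be ranked against nothing. Compound 3 `CCNC(=O)Nc1sc2ccccc2c1C(=O)N1CCN(C2CCN(C(=O)OC(C)C)CC2)CC1` differs from it in one place: methyl in place of hydrogen on a saturated chain carbon bound to an oxygen next to a carbonyl group and a saturated chain carbon, which reads as ethoxycarbonyl to isopropoxycarbonyl. Going by the values given here, no measured step informs this change, so no shift beyond the scatter is assumed in this assay. The expected size of the step of a 1.1-fold lower number from compound 2 to compound 3 (0.06 log units; within the scatter) stays within the scatter. For compound 3 the estimated value is 200 nM, with an expected range from 80 nM to 500 nM.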

Compound 3, half-maximal inhibitory concentration: 208 nM
Compound 3: middle estimate off by 1.0-fold (0.02 log units), on the low side; measured number inside the range.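

In this assay, for the compounds shown here, there is now a first step at this position: a 1.1-fold lower number from compound 2 to compound 3 (0.04 log units; within the scatter) means that ethoxycarbonyl and isopropoxycarbonyl cannot be told apart on this read-out. Adding methyl on this saturated chain carbon therefore leaves the number within the scatter of the parent. No supporting data bear on why this is so.

Compound 1 has no number and adds no comparison. From the compounds shown here alone, whether a longer chain such as butoxycarbonyl, or benzyloxycarbonyl, would also stay within the scatter remains open.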